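Replacing the Dichlorophenyl Group in an Aorta Inhibition Series

The compounds below may be only part of what the source reports. "The series", "measured", "known", "first", "only" and "open" are said of these compounds alone.

Compound 1, `COc1nc(-c2cc3ccccc3o2)cc(-c2ccc(Cl)cc2Cl)c1C#N`: 322000 nM
Compound 2, `CCOc1nc(-c2cc3ccccc3o2)cc(-c2ccc(Cl)cc2Cl)c1C#N`: 442000 nM
Compound 3, `COc1cc(-c2cc(-c3cc4ccccc4o3)nc(OC)c2C#N)cc(OC)c1OC`: 310000 nM

In a functional assay on aorta (strain Wistar) for inhibition, with Thoracic aorta (Rattus norvegicus) as the target (a lower number here means a stronger inhibitor, a higher number a weaker inhibitor), compound 2 gives 442000 nM. Compound 1 gives 322000 nM and compound 3 gives 310000 nM, so neither is separated from compound 2 beyond the scatter, and compound 2 does not stand apart from the other two. The new compound 4, `CCOc1nc(-c2cc3ccccc3o2)cc(-c2ccc(N(C)C)cc2)c1C#N`, differs from compound 2 by 4-(dimethylamino)phenyl in place of 2,4-dichlorophenyl on an aromatic carbon. For the measured compounds named here, the only measured step, a 1.4-fold higher number from compound 1 to compound 2 (0.14 log units; within the scatter), concerns the ethoxy group and does not bear on this change. Compound 1 and compound 3 carry different groups in this place, yet their two values lie within the scatter of each other. Compound 4 is therefore expected to give 400000 nM, in the range 150000 nM to 1000000 nM. That expectation amounts to a 1.1-fold lower number from compound 2 to compound 4 (0.04 log units; within the scatter), no change beyond the scatter.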

Compound 4, half-maximal inhibitory concentration: 338000 nM
The estimate for compound 4 lay 1.2-fold (0.07 log units) above the measured number; measured number inside the range.
By their numbers in this assay, from the lowest: compounds 3, 1, 4 and 2 (each within the scatter of the next).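

In this assay, the change at this position, opposite the ring nitrogen, gives a 1.3-fold lower number from compound 2 to compound 4 (0.12 log units; within the scatter) and so shows that, with the ethoxy group in place, 4-(dimethylamino)phenyl and 2,4-dichlorophenyl are not separated beyond the scatter. The exchange removes both chlorines and adds a hydrogen-bond acceptor, yet the number does not shift measurably. The compounds shown leave open whether a carboxylic acid, a primary amine or a saturated ring at this position would move the number beyond the scatter. Nothing available explains why this exchange leaves the number within the scatter.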